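Chloro in place of hydrogen on the shared core

The compounds below may be only part of what the source reports. "The series", "measured", "known", "first", "only" and "open" are said of these compounds alone.

- Compound 1 `Cc1cccc(Nc2ncc(C)c(Nc3ccc4nc[nH]c4c3)n2)c1` gives 6600 nM here
- Compound 2 `Cc1cccc(Nc2nccc(Nc3ccc4nc[nH]c4c3)n2)c1` gives 20000 nM here

In an ADME assay on HepG2 cells (Homo sapiens) for inhibition, read by fluorescence and resazurin assay, with a stated time of 72 h (on this read-out higher numbers stand for weaker inhibition and lower numbers for stronger inhibition), compound 2 gives the higher of the two numbers (20000 nM). Compound 3 `Cc1cccc(Nc2ncc(Cl)c(Nc3ccc4nc[nH]c4c3)n2)c1` carries chloro in place of hydrogen on an aromatic carbon. Within the data shown here, the one measured step bearing on this is hydrogen in place of methyl on an aromatic carbon (a 3.0-fold higher number from compound 1 to compound 2 (0.48 log units; beyond the scatter)), modest and beyond the scatter. Read in reverse, it suggests a modest move to a lower number, though no chloro compound has been measured. The expected step is modest (a 3.1-fold lower number from compound 2 to compound 3 (0.49 log units; beyond the scatter)). Compound 3 is estimated at 6500 nM with an expected range from 2200 nM to 18000 nM in this series.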

Compound 3, half-maximal inhibitory concentration: 7400 nM
Estimate against measurement, compound 3: 1.1-fold (0.06 log units) below; low and high end bracket the measured number.
By their numbers in this assay, from the lowest: compounds 1 and 3 (each within the scatter of the next); then compound 2.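

In this assay, chloro on this aromatic carbon moves the number down from the hydrogen compound (a 2.7-fold lower number from compound 2 to compound 3 (0.43 log units; beyond the scatter)), while exchanging methyl for chloro leaves it unresolved (a 1.1-fold higher number from compound 1 to compound 3 (0.05 log units; within the scatter)). Two different substituents at this position, methyl and chloro, therefore each stand apart from hydrogen but not from each other. No measurement at hand accounts for this shift.

Open, on these data alone, is whether a methoxy group, an amine or a nitrile at this carbon would track with methyl and chloro or with hydrogen. Also open, as far as these compounds go, is whether the same change would hold on a core carrying a different group in place of the (3-methylphenyl)amino group.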